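The compounds below may be only part of what the source reports. "The series", "measured", "known", "first", "only" and "open" are said of these compounds alone.

Working notes on a functional assay on LNCaP cells (Homo sapiens) for cytotoxicity, read by sulforhodamine B assay, with a stated time of 72 h; a lower number here means a stronger inhibitor, a higher number a weaker inhibitor. Among the compounds with values here, compound 1 `COc1cc(/C=C/C(=O)/C=C(O)/C=C/c2ccc(OC(C)(C)C(=O)Nc3ccc(C#N)c(C(F)(F)F)c3)c(OC)c2)ccc1O` gives 55000 nM, the only actual number so far. Compound 2 `COc1cc(/C=C/C(=O)/C=C(O)/C=C/c2ccc(OC(C)(C)C(=O)Nc3ccc(Cl)c(C(F)(F)F)c3)c(OC)c2)ccc1O` reads > 100000 nM, which is a limit of the assay. Compound 3 `COc1cc(/C=C/C(=O)/C=C(O)/C=C/c2ccc(OC(C)(C)C(=O)Nc3ccc(C)c(C(F)(F)F)c3)c(OC)c2)ccc1O` reads > 100000 nM, which is also a limit.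

Compound 4 `COc1ccc(/C=C/C(=O)/C=C(O)/C=C/c2ccc(OC(C)(C)C(=O)Nc3ccc(C#N)c(C(F)(F)F)c3)c(OC)c2)cc1OC` differs from compound 1 by methyl in place of hydrogen on an oxygen on an aromatic ring, so that 4-hydroxy-3-methoxyphenyl becomes 3,4-dimethoxyphenyl.

The measured steps are an at least 1.8-fold higher number from compound 1 to compound 2 (0.25 log units; that floor lies within the scatter), an at least 1.8-fold higher number from compound 1 to compound 3 (0.25 log units; that floor lies within the scatter) and a step that the two limits leave unreadable from compound 2 to compound 3. All three exchange groups on an aromatic carbon, and none touches the hydroxy group, so none bears directly on this change. The first two have floors within the scatter, and the third cannot be read.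

No step beyond the scatter is therefore expected in this assay, and no direction can be assigned. The anchor is compound 1 at 55000 nM. The expected result is a 1.1-fold higher number from compound 1 to compound 4 (0.04 log units; within the scatter). For compound 4 the estimated value is 60000 nM, with an expected range of 25000 nM to 100000 nM.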

Compound 4, half-maximal inhibitory concentration: > 100000 nM
Compound 4 was reported as a limit; the forecaster's own chance of this, stated with the estimate: 35%; middle value at least 1.6-fold (0.22 log units) away from the limit.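

In this assay, within the data shown here, the change from hydroxy to methoxy gives an at least 1.8-fold higher number from compound 1 to compound 4 (0.25 log units; that floor lies within the scatter), the first reading at the 4-hydroxy-3-methoxyphenyl end of the series. Compound 4 reads as a limit of the assay, so this floor does not establish a loss beyond the scatter, though no number was obtained once the hydroxy group was capped. Compound 1 therefore remains the only compound with an actual number, and the series has little readable range left: the limit of > 100000 nM in this assay, at which 3 of the 4 values shown sit.

As far as these compounds go, whether an ethoxy group on that oxygen, or an amine or a carboxylic acid in place of the hydroxy group, would give a number stays open. Also open, from the compounds shown here alone, is how far compound 4 lies from compound 1, and whether the hydroxy group matters at all in this assay.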